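Plasma free fraction across four related acids and an alcohol

The compounds below may be only part of what the source reports. "The series", "measured", "known", "first", "only" and "open" are said of these compounds alone.

Measured so far in an ADME assay on the whole organism (plasma, Rattus norvegicus) for protein binding, using cassette dosing, at a dose of 1 mg/kg; on this read-out lower numbers stand for a smaller free fraction and higher numbers for a larger free fraction:
compound 1 `CC(C)Oc1ccc(/N=c2\[nH]c(=O)n(CC(C)(C)C(=O)O)c(=O)n2Cc2ccc(Cl)cc2)cc1Cl` gives 0.003
compound 2 `CC(C)Oc1ccc(Nc2nc(=O)n(CCO)c(=O)n2Cc2ccc(Cl)cc2)cc1Cl` gives 0.001
compound 3 `C[C@@H](Cn1c(=O)[nH]/c(=N\c2ccc(Oc3ccsn3)cc2)n(Cc2ccc(Cl)cc2)c1=O)C(=O)O` gives 0.012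

Compound 3 stands highest of the three numbers; compound 1 is nearest and compound 2 furthest, and both gaps lie beyond the usual scatter of repeated measurements. Compound 4 `C[C@@H](Cn1c(=O)[nH]/c(=N\c2ccc(Oc3ccc(F)cn3)cc2)n(Cc2ccc(Cl)cc2)c1=O)C(=O)O` is not yet measured. It differs from compound 3 in one place: 5-fluoropyridin-2-yl in place of 1,2-thiazol-3-yl on an oxygen on an aromatic ring. Going by the values given here, no step between measured compounds is known for this kind of change, so the expectation rests on compound 3 alone. The step of a 1.2-fold lower number from compound 3 to compound 4 (0.08 log units; within the scatter) is expected to be small, within the scatter, with no clear direction. For compound 4 the unbound fraction is estimated at 0.01, in the range 0.004 to 0.025.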

Compound 4, unbound fraction: 0.011
The estimate for compound 4 lay 1.1-fold (0.04 log units) below the measured number; the measured number falls inside the stated range.
By their numbers in this assay, from the lowest: compound 2; then compound 1; then compounds 4 and 3 (each within the scatter of the next).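

In this assay the change from 1,2-thiazol-3-yl to 5-fluoropyridin-2-yl on the oxygen gives a 1.1-fold lower number from compound 3 to compound 4 (0.04 log units; within the scatter) with the rest of the molecule unchanged. For this pair, a six-membered aromatic ring with 1 hetero atom and a five-membered aromatic ring with 2 hetero atoms cannot be told apart on free fraction. No supporting measurement bears on why the two groups read alike. Still open, as far as these compounds go, is whether a ring on that oxygen carrying an amine or a nitrile would read differently, or whether a plain alkyl group there would.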